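A few compounds are considered here, and "the series" means these few. Any claim that something is new, unique, unknown or untested is made for them only; others in the source may bear on it.

Of the compounds shown here, two carry numbers so far. In a functional assay on LOX IMVI cells (Homo sapiens) for inhibition, read by sulforhodamine B assay, with a stated time of 48 h (on this read-out higher numbers stand for weaker inhibition of growth and lower numbers for stronger inhibition of growth), compound 2 `COc1cc(-c2nn(-c3cccc(NC(=O)Nc4cc(C(F)(F)F)cc(C(F)(F)F)c4)c3)cc2-c2ccncc2)ccc1Cl` gives 783 nM, the lowest of the two numbers. Among the measured compounds shown here, compound 1 `O=C(Nc1cccc(-n2cc(-c3ccncc3)c(-c3ccc(Cl)c(O)c3)n2)c1)Nc1cccc(C(F)(F)F)c1` gives 2530 nM in this assay; no step is computed between these two, and set side by side the values show compound 1 as the higher one, beyond the scatter. Compound 3 `O=C(Nc1cccc(-n2cc(-c3ccncc3)c(-c3ccc(Cl)c(O)c3)n2)c1)Nc1cc(C(F)(F)F)cc(C(F)(F)F)c1` has not yet been measured. Relative to compound 2 the change is hydrogen in place of methyl on an oxygen on an aromatic ring. For the measured compounds named here, no measured pair isolates this change, so its size cannot be read from the data at hand. The expected step is a 1.5-fold higher number from compound 2 to compound 3 (0.19 log units; within the scatter), estimated as small, within or only modestly beyond the scatter, with no firm direction. Compound 3 is accordingly expected at about 1200 nM in this assay, within a range of 400 nM to 4000 nM.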

Compound 3, concentration for 50% growth inhibition: 712 nM
Beside the measured number, compound 3's estimate is 1.7-fold (0.23 log units) above it; low and high end bracket the measured number.
By their numbers in this assay, from the lowest: compounds 3 and 2 (each within the scatter of the next); then compound 1.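

In this assay, methoxy to hydroxy on the 4-chloro-3-methoxyphenyl group gives a 1.1-fold lower number from compound 2 to compound 3 (0.04 log units; within the scatter), so this oxygen position accepts either a methyl or a hydrogen without a step beyond the scatter, at least in this one pair. Trifluoromethyl in place of hydrogen on an aromatic carbon gives a 3.6-fold lower number from compound 1 to compound 3 (0.55 log units; beyond the scatter), the only single change so far that moves the number beyond the scatter. No evidence at hand bears on what lies behind either step.

Whether methoxy and hydroxy also read alike when that added trifluoromethyl is replaced by hydrogen remains open, as the compounds shown include no methoxy partner for compound 1. Also open, going by these compounds, is how a longer group on that oxygen, such as ethyl, or an amine in place of the hydroxy would read.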